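Amide exchange from compound 3 to compound 4

A few compounds are considered here, and "the series" means these few. Any claim that something is new, unique, unknown or untested is made for them only; others in the source may bear on it.

In a functional assay on MCF7 cells (Homo sapiens) for antiproliferative activity, read by MTT assay, with a stated time of 48 h (a lower number here means a stronger inhibitor, a higher number a weaker inhibitor), compound 1 (`CCN(CC)CCNC(=O)c1ccc(C(CC)(CC)c2ccc(OCCC(O)(CC)CC)c(C)c2)n1CC`) gives 550 nM and compound 3 (`CCn1c(C(=O)NC(CC(=O)O)C(=O)OC)ccc1C(CC)(CC)c1ccc(OCCC(O)(CC)CC)c(C)c1`) gives 10200 nM as the higher of the two exact numbers. Compound 2 (`C#CC(C)OC(=O)c1ccc(C(CC)(CC)c2ccc(OCCC(O)(CC)CC)c(C)c2)n1CC`) gives > 50000 nM as a limit of the assay, not a number. The data show a 19-fold higher number from compound 1 to compound 3 (1.27 log units; beyond the scatter) as the gap between the two exact numbers, and an at least 4.9-fold lower number from compound 2 to compound 3 (0.69 log units; beyond the scatter) against the limit.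

Compound 4 (`CCn1c(C(=O)N(C)CCO)ccc1C(CC)(CC)c1ccc(OCCC(O)(CC)CC)c(C)c1`) is still unmeasured. Its change is a group of 5 heavy atoms (3 carbon, 1 nitrogen, 1 oxygen; no ring) in place of a group of 10 heavy atoms (5 carbon, 1 nitrogen, 4 oxygen; no ring), on a carbonyl carbon on a carbonyl carbon whose other neighbours are: aromatic carbon. The entering group is (2-hydroxyethyl)(methyl)amino, with no net charge. For the measured compounds named here, no measured step makes this exchange. The nearest steps at this carbonyl carbon are an at least 90-fold higher number from compound 1 to compound 2 (1.95 log units; beyond the scatter) and an at least 4.9-fold lower number from compound 2 to compound 3 (0.69 log units; beyond the scatter) and they show that changes here can be large, but neither fixes a direction for compound 4. The expectation therefore starts from compound 3 at 10200 nM and allows a wide range. The expected change is small, a 1.7-fold lower number from compound 3 to compound 4 (0.23 log units; within the scatter) and within the scatter, with a slight lean to a lower number. In this assay the estimate for compound 4 is 6000 nM and the value is expected between 1500 nM and 25000 nM in most repeat measurements.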

Compound 4, half-maximal inhibitory concentration: 2870 nM
Compound 4: the middle estimate sits 2.1-fold (0.32 log units) above what was measured, within the range that was stated.
By their numbers in this assay, from the lowest: compound 1; then compound 4; then compound 3. At a limit, above all of these: compound 2.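

In this assay, placing (2-hydroxyethyl)(methyl)amino on the carbonyl carbon in place of the larger group of compound 3 gives a modest gain (a 3.6-fold lower number from compound 3 to compound 4 (0.55 log units; beyond the scatter)), so a small uncharged group with a single hydrogen-bond donor is enough to recover part of the activity at this position. It does not reach the level of the (2-(diethylamino)ethyl)amino amide (a 5.2-fold higher number from compound 1 to compound 4 (0.72 log units; beyond the scatter)), which keeps that amide as the lowest number in the set and shows that amides at this carbonyl carbon are separated by more than the scatter. The exchange of (1-methylprop-2-yn-1-yl)oxy for (2-hydroxyethyl)(methyl)amino is the largest new step (an at least 17-fold lower number from compound 2 to compound 4 (1.24 log units; beyond the scatter)), but it is read against a limit of the assay and not against a number: (the limit of > 50000 nM in this assay, at which 1 of the 4 values shown sits).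

The step from compound 3 changes the size, the donor count and the acceptor count of the group together, so these cannot be separated here, and compound 4 also differs from compound 1 in carrying no amide hydrogen. On these data alone, how a cyclic amine such as morpholine or piperazine, or a longer hydroxyalkyl chain, would behave on this carbonyl carbon remains open.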